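A few compounds are considered here, and "the series" means these few. Any claim that something is new, unique, unknown or untested is made for them only; others in the source may bear on it.

Compound 1 `COc1ccc(-c2cc(/C=C/C(=O)c3ccc(N)cc3)[nH]n2)cc1`: 55500 nM
Compound 2 `COc1cc(-c2cc(/C=C/C(=O)c3ccc(Cl)c(Cl)c3)[nH]n2)cc(OC)c1OC`: > 100000 nM
Compound 3 `COc1ccc(C(=O)/C=C/c2cc(-c3cc(OC)c(OC)c(OC)c3)n[nH]2)cc1`: > 100000 nM

Among the compounds with values here, in a functional assay on MDA-MB-231 cells (Homo sapiens) for inhibition, read by sulforhodamine B assay, with a stated time of 48 h (a higher number here means that more compound is tolerated, a lower number that less compound is tolerated), compound 1 gives 55500 nM, the only plain number among the three measured compounds. For compound 2 this assay reports only a limit, > 100000 nM. For compound 3 it likewise reports only a limit, > 100000 nM. Within the data shown here, the one recorded step, a step that the two limits leave unreadable from compound 2 to compound 3, therefore cannot be read, since both of those values sit at the limit of > 100000 nM in this assay, at which 2 of the 3 values shown sit. Compound 4 `COc1ccc(-c2cc(/C=C/C(=O)c3ccc(N)cc3)[nH]n2)cc1OC` differs from compound 1 by methoxy in place of hydrogen on an aromatic carbon. Among the measured compounds shown here, no measured step involves this change, so the expectation rests on compound 1 alone. A shift within the usual scatter is expected, a 1.1-fold higher number from compound 1 to compound 4 (0.03 log units; within the scatter). For compound 4 the estimated result in this assay is 60000 nM, with a range from 25000 nM to 150000 nM.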

Compound 4, concentration lethal to 50% of the cells: 53900 nM
Compound 4: middle estimate off by 1.1-fold (0.05 log units), on the high side, and the stated range covers the measured number.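

Placing methoxy in place of hydrogen on the aromatic carbon ortho to a methoxy group gives a 1.0-fold lower number from compound 1 to compound 4 (0.01 log units; within the scatter) in this assay, the first readable step at this position. In this pair, then, the added methoxy group leaves the number unchanged within the usual scatter. Nothing shown here explains why the number holds steady. From the compounds shown here alone, whether an amine, a carboxylic acid or a longer chain such as ethoxy at this position would shift the number remains open. So does whether methoxy behaves the same way when the other parts of the molecule differ.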